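Varying the acyl group on the pyrrolidin-2-yl of compound 3

The source may report more compounds than this note shows. Statements on the series, on what has been measured and on what is new or still open speak of the compounds shown alone.

Measured compounds in an assay on isolated protein for binding affinity to secreted frizzled-related protein 1 (Homo sapiens), read by fluorescence; on this read-out lower numbers stand for stronger inhibition and higher numbers for weaker inhibition:
compound 1 `O=C(Cn1ccnc1)N1CCC(NS(=O)(=O)c2cc(S(=O)(=O)c3ccccc3)ccc2C(F)(F)F)CC1` gives 30 nM
compound 2 `O=C1CC[C@@H](C(=O)N2CCC(NS(=O)(=O)c3cc(S(=O)(=O)c4ccccc4)ccc3C(F)(F)F)CC2)N1` gives 90 nM
compound 3 `CC(C)C(=O)N1CCC[C@H]1C(=O)N1CCC(NS(=O)(=O)c2cc(S(=O)(=O)c3ccccc3)ccc2C(F)(F)F)CC1` gives 40 nM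

Compound 3 sits second highest of the three numbers. Its nearest neighbour is compound 1, with a 1.3-fold higher number from compound 1 to compound 3 (0.12 log units; within the scatter), so the two are not separated. Compound 2 stands furthest from it, with a 2.3-fold lower number from compound 2 to compound 3 (0.35 log units; beyond the scatter), a modest gap.

Compound 4 `CN(C)CC(=O)N1CCC[C@H]1C(=O)N1CCC(NS(=O)(=O)c2cc(S(=O)(=O)c3ccccc3)ccc2C(F)(F)F)CC1` is the next member. The change from compound 3 is (dimethylamino)methyl in place of isopropyl on a carbonyl carbon. For the measured compounds named here, no measured step exchanges one acyl group for another on that carbonyl carbon; the three steps known all swap the whole substituent on the carbonyl carbon of the shared core, and they were a 3.0-fold higher number from compound 1 to compound 2 (0.48 log units; beyond the scatter), a 1.3-fold higher number from compound 1 to compound 3 (0.12 log units; within the scatter) and a 2.3-fold lower number from compound 2 to compound 3 (0.35 log units; beyond the scatter). Across those swaps the spread stayed modest, so a small group exchange one bond further out is expected to move this assay little, likely not beyond the scatter, in either direction.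

Compound 4 is therefore estimated at 45 nM, within 20 nM to 110 nM. The expected step is a 1.1-fold higher number from compound 3 to compound 4 (0.05 log units; within the scatter).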

Compound 4, half-maximal inhibitory concentration: 90 nM
Beside the measured number, compound 4's estimate is 2.0-fold (0.30 log units) below it; low and high end bracket the measured number.
By their numbers in this assay, from the lowest: compounds 1 and 3 (each within the scatter of the next); then compounds 2 and 4 (each within the scatter of the next).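

In this assay, (dimethylamino)methyl in place of isopropyl on a carbonyl carbon gives a 2.3-fold higher number from compound 3 to compound 4 (0.35 log units; beyond the scatter), so the acyl group on the pyrrolidin-2-yl is a position where a single exchange can move the number beyond the scatter, if only modestly. The same exchange changes how this pyrrolidin-2-yl series sits against the other substituents: a 1.3-fold higher number from compound 1 to compound 3 (0.12 log units; within the scatter) had left those two compounds unseparated, whereas the new compound shows a 3.0-fold higher number from compound 1 to compound 4 (0.48 log units; beyond the scatter) and, against the 5-oxopyrrolidin-2-yl amide, no change at the digits printed from compound 2 to compound 4 (within the scatter). No measurement at hand accounts for the step from isopropyl to (dimethylamino)methyl.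

With only these two acyl groups, the effect of the nitrogen cannot be told apart from that of the change in the carbon chain, and an all-carbon group such as isobutyl or tert-butyl on the same carbonyl carbon would bear on this. Also open, as far as these compounds go, is how a primary amine such as aminomethyl, a carboxylic acid or a longer chain at this place would read, including whether any acyl group gives a number clearly lower than that of compound 3 at 40 nM.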